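Methylamino in Place of Methyl on Compound 3

A few compounds are considered here, and "the series" means these few. Any claim that something is new, unique, unknown or untested is made for them only; others in the source may bear on it.

Of the compounds shown here, three built on one shared core have been measured in a functional assay on OS-RC-2 cells (Homo sapiens) for cytotoxicity, read by MTT assay, with a stated time of 72 h; a lower number here means a stronger inhibitor, a higher number a weaker inhibitor. Compound 1 `O=C(Nc1ccc(-n2ncc3c(Cl)cccc32)cc1)Nc1ccc(Cl)c(C(F)(F)F)c1` gives 3100 nM, compound 2 `O=C(Nc1ccc(-n2ncc3c(Br)cccc32)cc1)Nc1ccc(Cl)c(C(F)(F)F)c1` gives 9900 nM, and compound 3 `Cc1cccc2c1cnn2-c1ccc(NC(=O)Nc2ccc(Cl)c(C(F)(F)F)c2)cc1` gives 32000 nM. Compound 3 therefore stands with the highest number of the three: a 10-fold higher number from compound 1 to compound 3 (1.01 log units; beyond the scatter) and a 3.2-fold higher number from compound 2 to compound 3 (0.51 log units; beyond the scatter), both beyond the usual scatter, while a 3.2-fold higher number from compound 1 to compound 2 (0.50 log units; beyond the scatter).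

Compound 4 `CNc1cccc2c1cnn2-c1ccc(NC(=O)Nc2ccc(Cl)c(C(F)(F)F)c2)cc1` differs from compound 3 in one place: methylamino in place of methyl on an aromatic carbon. None of the three measured steps covers a change of this kind; they compare chloro, bromo and methyl against one another at that same place, and the largest move among them was a 10-fold higher number from compound 1 to compound 3 (1.01 log units; beyond the scatter). Those steps show that what sits at this place can shift the number a good deal, but they give no direction for methylamino, a group unlike any of the three already tried. Among the measured compounds shown here, with no comparable step in the set, the expectation for compound 4 is a number near that of compound 3, and the expected step is a 1.1-fold lower number from compound 3 to compound 4 (0.03 log units; within the scatter). Compound 4 is thus estimated at 30000 nM, with a range from 8000 nM to 100000 nM to reflect the missing precedent.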

Compound 4, half-maximal inhibitory concentration: 10600 nM
Estimate against measurement, compound 4: 2.8-fold (0.45 log units) above; low and high end bracket the measured number.
By their numbers in this assay, from the lowest: compound 1; then compounds 2 and 4 (each within the scatter of the next); then compound 3.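

In this assay, the step from methyl to methylamino gives a 3.0-fold lower number from compound 3 to compound 4 (0.48 log units; beyond the scatter) and adds a nitrogen to the group at this place. This shows that a group of a different kind from chloro, bromo and methyl can also move the number, and that here it moves it in the stronger direction. Methylamino does not separate from bromo, with a 1.1-fold higher number from compound 2 to compound 4 (0.03 log units; within the scatter) as the step between them, but it does not reach chloro, as a 3.4-fold higher number from compound 1 to compound 4 (0.53 log units; beyond the scatter) shows, so compound 1 keeps the lowest number among these four. No measurement here bears on what lies behind these shifts.

The compounds shown leave open whether the gain depends on the nitrogen itself or on the methyl attached to it, a question that a plain amine and a dimethylamino group at the same place could help to settle. They also leave open how other groups joined through a heteroatom, such as methoxy or an ethylamino chain, would compare with chloro on this shared core.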